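Swapping the aryl ether on a diaminoquinoxaline core

The source may hold more compounds than are shown below. What is called first, only, known or untested is meant among the compounds shown, and "the series" means these compounds.

Measured compounds:
- compound 1, `Nc1cc(N)c2nc(-c3ccccc3)c(Oc3ccc(Cl)c(Cl)c3)nc2c1`: 20400 nM
- compound 2, `CCOC(=O)[C@H](CCC(=O)O)NC(=O)c1ccc(Sc2nc3cc(N)cc(N)c3nc2-c2ccccc2)cc1`: 28200 nM
- compound 3, `CCOC(=O)[C@H](CCC(=O)O)NC(=O)c1ccc(Oc2nc3cc(N)cc(N)c3nc2-c2ccccc2)cc1`: 30200 nM

Of the compounds shown here, three sharing the diamino-substituted core of compound 1 have been tested in a functional assay on COLO 205 cells (Homo sapiens) for inhibition, read by sulforhodamine B assay, with a stated time of 48 h; a higher number here means a weaker inhibitor of growth, a lower number a stronger inhibitor of growth. Compound 1 gives 20400 nM in this assay, the lowest of the three numbers; its nearest neighbour is compound 2 with 28200 nM, and the furthest is compound 3 with 30200 nM. Both gaps lie within the scatter, so the three compounds cannot be ranked against one another.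

The next compound, compound 4, `Nc1cc(N)c2nc(-c3ccccc3)c(NCc3ccc(F)cc3)nc2c1`, has not yet been tested. It differs from compound 1 in a single place: (4-fluorobenzyl)amino in place of 3,4-dichlorophenoxy on an aromatic carbon. For the measured compounds named here, no measured pair shows the effect of such a change, and the three values at hand all sit close together. On that basis, no step beyond the scatter is expected from compound 1 to compound 4 in this assay, in either direction; the estimated step of a 1.0-fold lower number from compound 1 to compound 4 (0.01 log units; within the scatter) is essentially flat. Compound 4 is therefore expected to give about 20000 nM, with a range from 6000 nM to 70000 nM.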

Compound 4, concentration for 50% growth inhibition: 2510 nM
For compound 4 the middle estimate is 8.0-fold (0.90 log units) above the measured one; measured number below the stated range.
By their numbers in this assay, from the lowest: compound 4; then compounds 1, 2 and 3 (each within the scatter of the next).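

In this assay, the position next to the ring nitrogen and ortho to the phenyl group proves sensitive to what it carries: (4-fluorobenzyl)amino in place of 3,4-dichlorophenoxy gives an 8.1-fold lower number from compound 1 to compound 4 (0.91 log units; beyond the scatter) and is the only step beyond the scatter among the compounds shown. The entering group differs in more than one way, with a hydrogen-bond donor that the leaving group lacks and fluorine instead of chlorine, so this single step cannot be assigned to any one of these features. No measurement at hand accounts for the step.

Going by these compounds, it remains open whether the amine link, the benzyl carbon or the halogen matters most; a benzyloxy group or a 3,4-dichlorobenzylamino group would help separate them. On these data alone, whether the same exchange would lower the numbers of compound 2 and compound 3 also remains open.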